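The compounds below may be only part of what the source reports. "The series", "measured", "known", "first", "only" and "open" are said of these compounds alone.

Measured so far:
compound 1 `C[C@@H](Oc1cc2ccn(CCC(=O)O)c2cc1Cl)c1ccccn1` — 2.17
compound 2 `O=C(O)CCn1c(=O)oc2cc(OCc3ccccc3)c(Cl)cc21` — 2.71

In a physicochemical assay for lipophilicity, read by HPLC, at pH 7.4 (a lower number here means a more polar compound, a higher number a more lipophilic compound), compound 2 stands highest of the two numbers; its nearest neighbour is compound 1, whose reading lies lower by a margin beyond the scatter. Compound 3 `O=C(O)CCn1c(=O)oc2cc(OCC3CCC3)c(Cl)cc21` is not yet measured in this assay. It differs from compound 2 by one change, (cyclobutyl in place of phenyl on a saturated chain carbon bound to an oxygen on an aromatic ring). Among the measured compounds shown here, with no measured pair showing this change, the step is expected to be small, if anything a slight decrease, and likely within the scatter: a number 0.21 log units lower from compound 2 to compound 3 (within the scatter). For compound 3 the estimated reading in this assay is 2.5, between 2.1 and 2.9.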

Compound 3, distribution coefficient: 2.9
Beside the measured number, compound 3's estimate is 0.40 log units below it; the range from low to high includes it.
By their numbers in this assay, from the lowest: compound 1; then compounds 2 and 3 (each within the scatter of the next).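

In this assay, the change from benzyloxy to cyclobutylmethoxy gives a number 0.19 log units higher from compound 2 to compound 3 (within the scatter), the first step measured at this position. The phenyl, an aromatic ring, can therefore give way to the smaller non-aromatic cyclobutyl with no change in this reading that can be told apart from scatter. Nothing available accounts for this result.

Still open, from the compounds shown here alone, is whether a ring carrying an amine, or a longer chain in place of the cyclobutylmethyl, would leave the reading equally undisturbed. This single pair also cannot show whether the same change would behave alike on another core.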